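From a Piperidinyl Side Chain to a Sulfamoyl Amine

The source may report more compounds than this note shows. Statements on the series, on what has been measured and on what is new or still open speak of the compounds shown alone.

Compound 2 `COC(=O)CC1CCN(C[C@H]2CN(c3ccc(-n4cc(-c5ccccn5)cn4)c(F)c3)C(=O)O2)CC1` was measured in a physicochemical assay for solubility, read by HPLC, with a stated time of 24 h (a higher number here means a more soluble compound, a lower number a less soluble compound), where compound 2 gives 92100 nM. Compound 1 `O=C1O[C@@H](CN2CCCCC2)CN1c1ccc(-n2cc(-c3ccccn3)cn2)c(F)c1` gives 219000 nM, and compound 3 `O=C1O[C@@H](CN2CCC(O)CC2)CN1c1ccc(-n2cc(-c3ccccn3)cn2)c(F)c1` gives 45900 nM. Compound 2 therefore stands second highest of the three numbers, with a 2.4-fold lower number from compound 1 to compound 2 (0.38 log units; beyond the scatter) and a 2.0-fold lower number from compound 2 to compound 3 (0.30 log units; within the scatter). Compound 4 `CN(C)S(=O)(=O)NC[C@H]1CN(c2ccc(-n3cc(-c4ccccn4)cn3)c(F)c2)C(=O)O1` carries a different change: (dimethylsulfamoyl)amino in place of 4-((methoxycarbonyl)methyl)piperidin-1-yl on a saturated chain carbon bound to a saturated ring carbon. The measured steps, a 2.4-fold lower number from compound 1 to compound 2 (0.38 log units; beyond the scatter), a 4.8-fold lower number from compound 1 to compound 3 (0.68 log units; beyond the scatter) and a 2.0-fold lower number from compound 2 to compound 3 (0.30 log units; within the scatter), all alter a substituent on the saturated ring carbon while that ring stays; here the whole ring leaves, so none of them bears directly on this swap. Each of those changes to the side chain lowered the number, and a larger drop is expected here. Compound 4 is estimated at 20000 nM, with a range from 5000 nM to 80000 nM. The expected step is a 4.6-fold lower number from compound 2 to compound 4 (0.66 log units; beyond the scatter).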

Compound 4, solubility: 472000 nM
The estimate for compound 4 lay 24-fold (1.37 log units) below the measured number, and the stated range ends below it.
By their numbers in this assay, from the lowest: compounds 3 and 2 (each within the scatter of the next); then compound 1; then compound 4.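

Compound 4 shows that the piperidin-1-yl ring can leave this saturated chain carbon altogether and the number in this assay can still rise: the open-chain (dimethylsulfamoyl)amino group gives a 5.1-fold higher number from compound 2 to compound 4 (0.71 log units; beyond the scatter) and a 10-fold higher number from compound 3 to compound 4 (1.01 log units; beyond the scatter). It also passes the plain piperidin-1-yl group, with a 2.2-fold higher number from compound 1 to compound 4 (0.33 log units; beyond the scatter), so the top of the series has moved. Nothing measured here offers a reason for this rise.

From the compounds shown here alone, whether the rise belongs to the sulfamoyl group or simply to losing the ring stays open. A methanesulfonamide or an acetamide on the same carbon could help separate the two.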